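A few compounds are considered here, and "the series" means these few. Any claim that something is new, unique, unknown or untested is made for them only; others in the source may bear on it.

In a functional assay on HCT-116 cells (Homo sapiens) for antiproliferative activity, read by MTT assay, with a stated time of 48 h (a lower number here means a stronger inhibitor, a higher number a weaker inhibitor), compound 1 `COc1cc(/C=C/C(C)=O)ccc1OCc1cn(-c2c(Cl)cccc2Cl)nn1` gives 2000 nM, the lowest number among the three measured compounds. Compound 2 `COc1cc(/C=C/C(C)=O)ccc1OCc1cn(-c2ccc([N+](=O)[O-])cc2)nn1` gives 96300 nM, and compound 3 `CCOC(=O)c1ccc(-n2cc(COc3ccc(/C=C/C(C)=O)cc3OC)nn2)cc1` gives 78900 nM; both of these numbers lie far above that of compound 1. The step of a 48-fold higher number from compound 1 to compound 2 (1.68 log units; beyond the scatter) is a large one, while the step of a 1.2-fold lower number from compound 2 to compound 3 (0.09 log units; within the scatter) shows that exchanging nitro for ethoxycarbonyl on the aromatic carbon barely moves the number. Compound 4 `COc1cc(/C=C/C(C)=O)ccc1OCc1cn(-c2ccc(C=O)cc2)nn1` differs from compound 1 in one place: 4-formylphenyl in place of 2,6-dichlorophenyl on an aromatic nitrogen. As in compound 2 and compound 3, the 2,6-dichlorophenyl is replaced by a phenyl carrying a single group, so the step from compound 1 to compound 2 is the closest guide, and a large rise in number, meaning weaker inhibition, is expected in this assay. Compound 4 is therefore expected to give 70000 nM, within a range from 20000 nM to 200000 nM. This estimate corresponds to an expected step of a 35-fold higher number from compound 1 to compound 4 (1.54 log units; beyond the scatter). Among the measured compounds shown here, the range is wide since the formyl group itself has no measured counterpart.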

Compound 4, half-maximal inhibitory concentration: 76200 nM
Beside the measured number, compound 4's estimate is 1.1-fold (0.04 log units) below it, and the stated range covers the measured number.
By their numbers in this assay, from the lowest: compound 1; then compounds 4, 3 and 2 (each within the scatter of the next).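

In this assay, 4-formylphenyl in place of 2,6-dichlorophenyl gives a 38-fold higher number from compound 1 to compound 4 (1.58 log units; beyond the scatter), so a third singly substituted phenyl now lands far from compound 1. The three groups on that phenyl also give numbers that cannot be told apart: formyl in place of nitro gives a 1.3-fold lower number from compound 2 to compound 4 (0.10 log units; within the scatter), and hydrogen in place of ethoxy on the carbonyl carbon gives a 1.0-fold lower number from compound 3 to compound 4 (0.02 log units; within the scatter), both within the scatter. No measurement of any property is available to explain the large gap between compound 1 and these three compounds.

Each of these three compounds differs from compound 1 both in losing the two chlorine atoms and in gaining a new group, so the two changes cannot be separated. A plain phenyl, a phenyl with a single chlorine and a phenyl carrying an amine would each help to show which change matters.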